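The source may report more compounds than this note shows. Statements on the series, on what has been measured and on what is new or still open speak of the compounds shown alone.

Measured in a functional assay on U-251 cells (Homo sapiens) for inhibition, read by sulforhodamine B assay, with a stated time of 72 h; on this read-out lower numbers stand for an effect already at smaller amounts and higher numbers for an effect only at larger amounts of compound:
- Compound 1 `CCC(=O)Oc1cccc2ccc(/C=C/c3ccccc3[N+](=O)[O-])nc12`: 10100 nM
- Compound 2 `O=C(/C=C/c1ccc([N+](=O)[O-])o1)c1ccc(Br)cc1`: 21400 nM
- Compound 3 `CC(C)(C)c1ccc(C(=O)/C=C/c2ccc([N+](=O)[O-])o2)cc1`: 44500 nM

Among these three, compound 3 has the highest number, so it needs the largest amount of compound for its effect in this assay. Compound 4 `O=C(/C=C/c1ccc([N+](=O)[O-])o1)c1ccc(-c2ccccc2)cc1` has not yet been measured. It replaces the tert-butyl of compound 3 with a phenyl on the same aromatic carbon: phenyl in place of tert-butyl on an aromatic carbon.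

Going by the values given here, only one measured step bears directly on this change, a 2.1-fold higher number from compound 2 to compound 3 (0.32 log units; beyond the scatter), which swaps the group at that carbon and is modest in size. Among the compounds with values here, compound 1 carries a different core and gives no step to compare. Within the data shown here, no measured compound yet carries the phenyl, so the direction is uncertain. A small move toward a lower number is expected, no larger than the modest step seen before and possibly lost in the scatter. The expected step is a 1.5-fold lower number from compound 3 to compound 4 (0.17 log units; within the scatter). For compound 4 the estimated value is 30000 nM, with an expected range from 12000 nM to 70000 nM.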

Compound 4, half-maximal effective concentration: 24600 nM
For compound 4 the middle estimate is 1.2-fold (0.09 log units) above the measured one; the measured number falls inside the stated range.
By their numbers in this assay, from the lowest: compound 1; then compounds 2, 4 and 3 (each within the scatter of the next, the first and the last beyond it).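

In this assay the phenyl on this aromatic carbon yields a 1.8-fold lower number from compound 3 to compound 4 (0.26 log units; within the scatter) and likewise a 1.1-fold higher number from compound 2 to compound 4 (0.06 log units; within the scatter) so the new group cannot be told apart from either bromo or tert-butyl by its number. Going by these compounds alone, of the three groups at this carbon, the only pair separated beyond the scatter is still bromo and tert-butyl, with a 2.1-fold higher number from compound 2 to compound 3 (0.32 log units; beyond the scatter) and phenyl does not fall clearly on either side of that gap. Nothing measured alongside these numbers offers an explanation for them.

What the compounds shown leave open is whether a group of another kind at this carbon, such as an amine or a carboxylic acid, would move the number beyond the scatter of these three. Within the data shown here, also open is whether any of this carries over to the core of compound 1, which shares no step with them.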